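From difluoro to dichloro on the phenyl ring

A few compounds are considered here, and "the series" means these few. Any claim that something is new, unique, unknown or untested is made for them only; others in the source may bear on it.

Values in an ADME assay on MDBK cells (Bos taurus) for cytotoxicity, read by MTT assay; a lower number here means that less compound is tolerated, a higher number that more compound is tolerated:
- compound 1 (`Cc1ccc(C(C)C)c(OCCCCCCN2C[C@H](O)[C@@H](O)[C@H](O)[C@H]2CO)c1`): 62000 nM
- compound 2 (`OC[C@@H]1[C@@H](O)[C@H](O)[C@@H](O)CN1CCCCCCOc1cc(F)ccc1F`): > 500000 nM, a limit of the assay and not a number
- compound 3 (`OC[C@@H]1[C@@H](O)[C@H](O)[C@@H](O)CN1CCCc1cccc(OC2CCCCC2)c1`): 390000 nM

Compound 2 stands at the limit of > 500000 nM in this assay, at which 1 of the 3 values shown sits. That makes it a limit, so its true position cannot be read as a number. Compound 1 and compound 3 do have numbers, and both sit on the side of the scale where less compound is tolerated.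

The next molecule is compound 4 (`OC[C@@H]1[C@@H](O)[C@H](O)[C@@H](O)CN1CCCCCCOc1cc(Cl)ccc1Cl`), which keeps everything in compound 2 except one group. It has 2,5-dichlorophenyl in place of 2,5-difluorophenyl on an oxygen on a saturated carbon.

Within the data shown here, no measured pair isolates this swap, so its size in this assay is a judgement. Compound 1 carries a different aromatic group on that oxygen and reads 62000 nM, which suggests that this part of the molecule can matter. A fall beyond the usual scatter therefore seems more likely than no change, and the expected step is an at least 3.3-fold lower number from compound 2 to compound 4 (0.52 log units; beyond the scatter). Compound 4 is estimated at 150000 nM, with an expected range from 50000 nM to 500000 nM.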

Compound 4, half-maximal cytotoxic concentration: 320000 nM
For compound 4 the middle estimate is 2.1-fold (0.33 log units) below the measured one; measured number inside the range.
By their numbers in this assay, from the lowest: compound 1; then compounds 4 and 3 (each within the scatter of the next). At a limit, above all of these: compound 2.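

In this assay, this position now has its first step that can be read, for 2,5-dichlorophenyl in place of 2,5-difluorophenyl on the oxygen: an at least 1.5-fold lower number from compound 2 to compound 4 (0.19 log units; that floor lies within the scatter). Compound 4 gives 320000 nM, so exchanging the two fluorines for two chlorines brings the value onto the measured scale, while the true size of the change could lie within the scatter or well beyond it. The step is only a floor and not a full size, because compound 2 sits at a limit of the assay and has no number of its own: the limit of > 500000 nM in this assay, at which 1 of the 4 values shown sits.

The compounds shown leave open how other groups on this oxygen would read, such as an unsubstituted phenyl or a 2,5-dibromophenyl, which could show whether the value tracks the kind of halogen at all. As far as these compounds go, a longer saturated chain carrying the 2,5-dichlorophenyl ether is also open, as is any comparison that starts from a measured number and not from a limit.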